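Aryl variation on the alkyne: toward compound 4

This account rests on a few compounds, and the source may have more. Where it says the series, first, only, none or still open, it means among the compounds named here.

Three compounds of the series have been measured in an ADME assay on HEK293 cells for agonist activity at metabotropic glutamate receptor 5 (Rattus norvegicus), read by fluorescence and calcium flux; on this read-out lower numbers stand for smaller maximal responses and higher numbers for larger maximal responses:

compound 1 `C[C@@H](NC(=O)c1ccc(C#Cc2ccccc2F)cn1)C(C)(C)O` — 29.6%
compound 2 `C[C@@H](NC(=O)c1ccc(C#Cc2ccc(F)cc2)cn1)C(C)(C)O` — 38.4%
compound 3 `Cc1cccc(C#Cc2ccc(C(=O)N[C@H](C)C(C)(C)O)nc2)c1` — 20.8%

Compound 3 stands lowest of the three. Its nearest neighbour is compound 1, a number 8.8 percentage points lower from compound 1 to compound 3 (within the scatter); the gap to compound 2 is larger, a number 17.6 percentage points lower from compound 2 to compound 3 (beyond the scatter). The remaining pair, a number 8.8 percentage points higher from compound 1 to compound 2 (within the scatter), also stays within the scatter.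

Compound 4 `C[C@@H](NC(=O)c1ccc(C#Cc2cccnc2)cn1)C(C)(C)O` continues the same variation of the aryl group on the triple-bonded carbon: pyridin-3-yl in place of 3-methylphenyl on a triple-bonded carbon. The three measured steps bear on it directly, since each exchanges this aryl group; two lie within the scatter and one is modest. For the measured compounds named here, no measured step involves pyridin-3-yl. The step of a number 7.2 percentage points higher from compound 3 to compound 4 (within the scatter) is therefore expected to stay within the scatter, with the estimate for compound 4 placed at 28%, in the range 13% to 43%.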

Compound 4, largest response reached (reported as efficacy), in percent of the reference or control that the assay uses: 25.9%
Beside the measured number, compound 4's estimate is 2.1 percentage points above it, within the range that was stated.
By their numbers in this assay, from the lowest: compounds 3, 4, 1 and 2 (each within the scatter of the next, the first and the last beyond it).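

Pyridin-3-yl brings a ring nitrogen and a hydrogen-bond acceptor to the triple-bonded carbon, yet in this assay it stays level with two carbon-only aryl groups (a number 5.1 percentage points higher from compound 3 to compound 4 (within the scatter); a number 3.7 percentage points lower from compound 1 to compound 4 (within the scatter)). Only 4-fluorophenyl stands apart from it (a number 12.5 percentage points lower from compound 2 to compound 4 (beyond the scatter)), so a ring nitrogen is tolerated here without a step beyond the scatter from those two groups. Nothing measured on hand accounts for these steps.
Open, going by these compounds, is how a non-aromatic group such as cyclohexyl would read at this place. Also open, on these data alone, is an aryl ring carrying an amine or a carboxylic acid.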